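One Chlorine Less: What to Expect for Compound 4

The source may report more compounds than this note shows. Statements on the series, on what has been measured and on what is new or still open speak of the compounds shown alone.

Compound 1 `O=c1c(C(=S)Nc2ccccc2)coc2cc(Cl)ccc12` gives 55% in a functional assay on PC-3 cells (Homo sapiens) for inhibition, read by sulforhodamine B assay, with a stated time of 48 h, tested at 100 uM; a higher number here means more inhibition of growth at the concentration tested, a lower number less inhibition of growth.
Compound 2 `O=c1c(C2N=C(c3ccccc3)SS2)coc2ccc(Cl)cc12` gives 62% in this assay.
Compound 3 `O=c1c(C2N=C(c3ccccc3)SS2)coc2cc(Cl)c(Cl)cc12` gives 70% in this assay.

Compound 2 stands second of the three numbers; compound 1 lies lower and compound 3 higher, both within the scatter. Compound 4 `O=c1c(C2N=C(c3ccccc3)SS2)coc2ccccc12` differs from compound 2 by hydrogen in place of chloro on an aromatic carbon. Among the measured compounds shown here, the only measured step of the same kind runs the other way: a number 8 percentage points higher from compound 2 to compound 3 (within the scatter). Taking a chloro away is therefore expected to move this assay little, perhaps slightly downward, but not beyond the scatter; a step of a number 7 percentage points lower from compound 2 to compound 4 (within the scatter) is expected. Compound 4 is estimated at 55%, with a range from 40% to 70%.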

Compound 4, percent growth inhibition at one concentration: 23%
Estimate against measurement, compound 4: 32 percentage points above; the measured number lies below the stated range.
By their numbers in this assay, from the lowest: compound 4; then compounds 1, 2 and 3 (each within the scatter of the next, the first and the last beyond it).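

In this assay, hydrogen in place of chloro on this aromatic carbon brings a number 39 percentage points lower from compound 2 to compound 4 (beyond the scatter). This single chloro therefore matters a great deal for compound 2, whereas the further chloro elsewhere on the same ring brings only a number 8 percentage points higher from compound 2 to compound 3 (within the scatter). No measurement at hand explains why this one atom counts for so much. Still open, going by these compounds, is whether bromo, methoxy or an amine on this carbon would hold the growth inhibition as chloro does. Equally open, on these data alone, is whether the same loss would appear with the thioamide side chain of compound 1.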